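From acetyl to ethyl on the aromatic oxygen

The source may hold more compounds than are shown below. What is called first, only, known or untested is meant among the compounds shown, and "the series" means these compounds.

In a functional assay on HeLa cells (Homo sapiens) for cytotoxicity, read by XTT assay, with a stated time of 24 h (on this read-out lower numbers stand for stronger inhibition and higher numbers for weaker inhibition), compound 1 (`Cc1cc(Cl)c2c(c1O)C(=O)C=CC2=O`), with hydrogen on the oxygen, gives 10100 nM. Compound 2 (`COc1c(C)cc(Cl)c2c1C(=O)C=CC2=O`), with methyl there, gives 41500 nM, and compound 3 (`CC(=O)Oc1c(C)cc(Cl)c2c1C(=O)C=CC2=O`), with acetyl there, gives 21800 nM. Compound 3 belongs to the upper pair of the three numbers, clear of the hydrogen compound: a 2.2-fold higher number from compound 1 to compound 3 (0.33 log units; beyond the scatter). Within that pair the two are not resolved: a 1.9-fold lower number from compound 2 to compound 3 (0.28 log units; within the scatter).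

Compound 4 (`CCOc1c(C)cc(Cl)c2c1C(=O)C=CC2=O`) is unmeasured and carries ethyl in place of acetyl on an oxygen on an aromatic ring. Within the data shown here, no ethyl example has been measured. Among the measured compounds shown here, the closest precedent is methyl, which gave a 4.1-fold higher number from compound 1 to compound 2 (0.61 log units; beyond the scatter), so compound 4 is expected to resemble compound 2 at 41500 nM. For compound 4 the expected step is a 1.8-fold higher number from compound 3 to compound 4 (0.26 log units; within the scatter), a small rise not clearly beyond the scatter. For compound 4 the estimate is 40000 nM, with an expected range of 20000 nM to 80000 nM.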

Compound 4, half-maximal inhibitory concentration: 33200 nM
Estimate against measurement, compound 4: 1.2-fold (0.08 log units) above, and the stated range covers the measured number.
By their numbers in this assay, from the lowest: compound 1; then compounds 3, 4 and 2 (each within the scatter of the next).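

Ethyl on the aromatic oxygen cannot be resolved in this assay from methyl there (a 1.3-fold lower number from compound 2 to compound 4 (0.10 log units; within the scatter)) or from acetyl there (a 1.5-fold higher number from compound 3 to compound 4 (0.18 log units; within the scatter)), so the three groups now form a single band in which no order can be read. Ethyl remains clear of hydrogen on the same oxygen (a 3.3-fold higher number from compound 1 to compound 4 (0.52 log units; beyond the scatter)), which makes it the third group, after methyl and acetyl, to give a higher number than the free hydroxyl of compound 1, with no listed compound going against this. Nothing available on these compounds explains the separation between hydrogen and the three groups.

Going by these compounds, whether a longer chain such as propyl, or a benzyl group, on this oxygen stays within the same band remains open. A chain ending in an amine or a carboxylic acid is equally untested against the free hydroxyl.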